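Heptyl in place of nitrophenyl on two related cores

The source may hold more compounds than are shown below. What is called first, only, known or untested is meant among the compounds shown, and "the series" means these compounds.

Of the compounds shown here, three have been measured. Compound 1 `O=[N+]([O-])c1ccc(C(c2c[nH]c3ccc(Br)cc23)c2c[nH]c3ccc(Br)cc23)cc1` gives 3100 nM in a functional assay on MCF7 cells (Homo sapiens) for inhibition, read by MTT assay, with a stated time of 48 h; on this read-out lower numbers stand for stronger inhibition and higher numbers for weaker inhibition. Compound 2 `CCCCCCCC(c1c[nH]c2ccc(Br)cc12)c1c[nH]c2ccc(Br)cc12` differs from compound 1 in one place, (heptyl in place of 4-nitrophenyl on a saturated chain carbon bound to two aromatic carbons), and in this assay compound 2 gives 5500 nM; the step is a 1.8-fold higher number from compound 1 to compound 2 (0.25 log units; within the scatter). Compound 3 `O=[N+]([O-])c1ccc(C(c2c[nH]c3ccc([N+](=O)[O-])cc23)c2c[nH]c3ccc([N+](=O)[O-])cc23)cc1` carries a different core from compound 1; how the two cores differ is not broken down here. In this assay compound 3 gives 22500 nM, the highest of the three numbers, beyond the scatter from both compound 1 and compound 2.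

Compound 4 `CCCCCCCC(c1c[nH]c2ccc([N+](=O)[O-])cc12)c1c[nH]c2ccc([N+](=O)[O-])cc12` has not yet been measured. It stands to compound 3 as compound 2 stands to compound 1: the change heptyl in place of 4-nitrophenyl on a saturated chain carbon bound to two aromatic carbons is the same change at the same place. Because the earlier step of a 1.8-fold higher number from compound 1 to compound 2 (0.25 log units; within the scatter) stayed within the scatter, a step of similar size is expected for compound 4, resting on that single pair, while the different core leaves room for a wider outcome. The expected step is a 1.5-fold higher number from compound 3 to compound 4 (0.18 log units; within the scatter). Compound 4 is estimated at 34000 nM in this assay, between 15000 nM and 80000 nM.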

Compound 4, half-maximal inhibitory concentration: 5800 nM
For compound 4 the middle estimate is 5.9-fold (0.77 log units) above the measured one, and the stated range ends above it.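

In this assay, heptyl in place of 4-nitrophenyl on a saturated chain carbon bound to two aromatic carbons gives a 3.9-fold lower number from compound 3 to compound 4 (0.59 log units; beyond the scatter), a step beyond the scatter, whereas the same change on the core of compound 1 stayed within it, so the two cores do not respond alike: the same change on two cores in this assay, a 1.8-fold higher number (0.25 log units; within the scatter) from compound 1 to compound 2 and a 3.9-fold lower number (0.59 log units; beyond the scatter) from compound 3 to compound 4, 6.9-fold (0.84 log units) apart, beyond the scatter of two such steps

This shows that, in this series, the step measured for this change on one core could not be carried over to the other core. Among the compounds shown here, it does not show which feature of the cores sets the two steps apart or why they differ, and each core contributes only a single pair of compounds.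

The compounds shown leave open how a third core would respond to the same change. They also leave open whether other groups on that chain carbon, such as a longer chain, an unsubstituted phenyl or a carboxylic acid, would separate the two cores in the same way.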